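The source may report more compounds than this note shows. Statements on the series, on what has been measured and on what is new or still open speak of the compounds shown alone.

In an assay on HEK293F cells for inhibition of AP2-associated protein kinase 1 (Homo sapiens), read by Western blot, with a stated time of 3 h (a lower number here means a stronger inhibitor, a higher number a weaker inhibitor), compound 1 `COC(=O)Nc1cc(-c2ccc(OC[C@@](C)(N)CC(C)C)c(C)c2)ccn1` gives 0.8 nM, compound 2 `CC(=O)Nc1cc(-c2ccc(OC[C@@H](N)CC(C)C)c(C)c2)ccn1` gives 1.1 nM, and compound 3 `CC(=O)Nc1cc(-c2cc(F)c(OC[C@@H](N)CC(C)C)cc2F)ccn1` gives 6.7 nM. Compound 2 therefore stands second highest of the three numbers: its nearest neighbour is compound 1, within the scatter, and its furthest is compound 3, beyond the scatter. Compound 4 `CC(=O)Nc1cc(-c2ccc(OC[C@@H](N)CC(C)C)cc2)ccn1` differs from compound 2 by hydrogen in place of methyl on an aromatic carbon, in words hydrogen in place of methyl on an aromatic carbon. Within the data shown here, no step between measured compounds isolates this change, so the expectation rests on compound 2 alone. The step from a 1.8-fold higher number from compound 2 to compound 4 (0.26 log units; within the scatter) is expected to be small, toward a higher number, and probably not beyond the scatter. Compound 4 is accordingly estimated at 2 nM, within a range from 0.7 nM to 6 nM.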

Compound 4, half-maximal inhibitory concentration: 8.1 nM
Compound 4: middle estimate off by 4.1-fold (0.61 log units), on the low side; the whole stated range lies below it.
By their numbers in this assay, from the lowest: compounds 1 and 2 (each within the scatter of the next); then compounds 3 and 4 (each within the scatter of the next).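

In this assay the change to hydrogen at this carbon, ortho to the (2-amino-4-methylpentyl)oxy group, gives a 7.4-fold higher number from compound 2 to compound 4 (0.87 log units; beyond the scatter) and so the methyl there counts for a real part of the inhibition of compound 2. This is the only step shown that isolates the position. Nothing measured here accounts for the size of the step.

Going by these compounds, whether ethyl, methoxy or chlorine at this carbon would keep the low number of compound 2 stays open. So does whether the same change would cost as much on the core of compound 1.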